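The source may report more compounds than this note shows. Statements on the series, on what has been measured and on what is new or still open speak of the compounds shown alone.

Three compounds sharing one core were tested in a functional assay on HeLa cells (Homo sapiens) for inhibition; on this read-out lower numbers stand for stronger inhibition of growth and higher numbers for weaker inhibition of growth. Compound 1, with the structure `O=C(OC1CCCCC1)c1ccsc1NC(=O)[C@@H]1CCCN1`, carries a cyclohexyl ester on the thiophene ring; in this assay compound 1 gives 92.8 ug/mL. Compound 2, with the structure `COC(=O)c1sccc1NC(=O)[C@@H]1CCCN1`, is a methyl ester on a differently connected core, and in this assay compound 2 gives 90.4 ug/mL. Compound 3, with the structure `COC(=O)c1ccsc1NC(=O)[C@H]1CCCN1`, is the methyl ester matching the connection pattern of compound 1 but with the opposite configuration on the pyrrolidine; in this assay compound 3 gives 91.4 ug/mL. The three numbers lie so close together that every difference between them falls within the usual scatter, so compound 1 cannot be separated from compound 2 or compound 3 on these data, and all three show only weak inhibition of growth.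

Compound 4, with the structure `O=C(OCC(Cl)(Cl)Cl)c1ccsc1NC(=O)[C@@H]1CCCN1`, has not yet been measured. It differs from compound 1 in one place: 2,2,2-trichloroethyl in place of cyclohexyl on an oxygen next to a carbonyl group. With the ester changed from cyclohexyl to methyl in compound 3 showing no shift beyond the scatter, the step from compound 1 to compound 4 is expected to be none beyond the scatter, written as a 1.1-fold lower number from compound 1 to compound 4 (0.04 log units; within the scatter). Compound 4 is therefore expected to give 85 ug/mL, within a range from 40 ug/mL to 130 ug/mL.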

Compound 4, concentration for 50% growth inhibition: > 250 ug/mL
Compound 4 gave a limit, no number; the forecaster's own chance of this, stated with the estimate: 20%; at least 2.9-fold (0.46 log units) between middle value and limit.
By their numbers in this assay, from the lowest: compounds 2, 3 and 1 (each within the scatter of the next). At a limit, above all of these: compound 4.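

In this assay, among these compounds, the earlier compounds gave no sign that the ester group matters, but exchanging the ester group gives an at least 2.6-fold higher number from compound 1 to compound 4 (0.43 log units; beyond the scatter), so what sits at this position can change the read-out, here towards weaker inhibition of growth. Going by these compounds, the true size of this step stays unknown, since compound 4 stands at a limit and not at a number: the limit of > 250 ug/mL in this assay, at which 1 of the 4 values shown sits. Cyclohexyl brings a ring of carbon only, whereas 2,2,2-trichloroethyl brings chlorine and no ring, and this one step cannot tell which of these differences matters.

Left open is how an ethyl ester, with neither a ring nor chlorine, or a free carboxylic acid at the same place would compare with compound 1, which would help separate the loss of the ring from the arrival of chlorine. Also open, on these data alone, is whether a single chlorine, as in a 2-chloroethyl ester, would be enough to shift the number beyond the usual scatter.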